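Swapping the Aryl Group on Compound 1

This account rests on a few compounds, and the source may have more. Where it says the series, first, only, none or still open, it means among the compounds named here.

Measured in a functional assay on HT-29 cells (Homo sapiens) for antiproliferative activity, read by MTT assay, with a stated time of 48 h; on this read-out higher numbers stand for weaker inhibition of growth and lower numbers for stronger inhibition of growth:
Compound 1 `COC(=O)N1N=C(c2ccc(OC)cc2)CC1c1cc(OC)c(OC)c(OC)c1`: 2550 nM
Compound 2 `COc1ccc(C2=NN(C(=O)OCc3ccccc3)C(c3cc(OC)c(OC)c(OC)c3)C2)cc1`: > 10000 nM

Among the measured compounds shown here, compound 1 gives 2550 nM, the only true number so far. Compound 2 gives > 10000 nM, which is a limit of this assay and not a number.

Compound 3 `COC(=O)N1N=C(c2cccc(Cl)c2)CC1c1cc(OC)c(OC)c(OC)c1` keeps the core of compound 1 but has 3-chlorophenyl in place of 4-methoxyphenyl on a carbon with a double bond to nitrogen. For the measured compounds named here, no step at this place has been measured. Going by the values given here, the one measured step, an at least 3.9-fold higher number from compound 1 to compound 2 (0.59 log units; beyond the scatter), puts phenyl in place of hydrogen elsewhere in the molecule, so it is only a loose guide. It shows that one change can raise the number, and it went towards weaker inhibition of growth. A small rise in this assay is therefore expected, with little certainty about its direction. The expected change is a 1.4-fold higher number from compound 1 to compound 3 (0.14 log units; within the scatter). The estimate for compound 3 is 3500 nM, with an expected range of 1000 nM to 10000 nM.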

Compound 3, concentration for 50% growth inhibition: 140 nM
The estimate for compound 3 lay 25-fold (1.40 log units) above the measured number, outside the stated range (below it).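

In this assay the exchange of 4-methoxyphenyl for 3-chlorophenyl gives an 18-fold lower number from compound 1 to compound 3 (1.26 log units; beyond the scatter) and shows that the group on this carbon with a double bond to nitrogen has a strong hold on growth inhibition. This is the first step shown at this position, and it runs towards stronger inhibition of growth, the opposite direction to the only earlier step, which lay elsewhere in the molecule. Nothing shown here accounts for the size of this gain.

The step changes both the substituent on the phenyl ring and where it sits, and the compounds shown do not separate these two changes. As far as these compounds go, whether plain phenyl, or an aminophenyl group, would keep the lower number at this position also remains open.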